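Triazolyl for methylsulfonyl compared across two cores

The source may report more compounds than this note shows. Statements on the series, on what has been measured and on what is new or still open speak of the compounds shown alone.

Compound 1 `CCOC(=O)C1CCN(c2ncnc(Oc3ccc(S(C)(=O)=O)cc3)c2[N+](=O)[O-])CC1` and compound 2 `CCOC(=O)C1CCN(c2ncnc(Oc3ccc(-n4cncn4)cc3)c2[N+](=O)[O-])CC1` share one core, while compound 3 `CCOC(=O)C1CCN(c2ncnc(Nc3ccc(S(C)(=O)=O)cc3)c2[N+](=O)[O-])CC1` and compound 4 `CCOC(=O)C1CCN(c2ncnc(Nc3ccc(-n4cncn4)cc3)c2[N+](=O)[O-])CC1` share another; the difference between the two cores is not broken down here. In a functional assay on HEK293 cells for agonist activity at Glucose-dependent insulinotropic receptor (Homo sapiens), read by cAMP accumulation (on this read-out lower numbers stand for an effect already at smaller amounts and higher numbers for an effect only at larger amounts of compound), compound 1 gives 1900 nM and compound 2 gives 2500 nM. The change between them, (1H-1,2,4-triazol-1-yl in place of methylsulfonyl on an aromatic carbon), produced a step of a 1.3-fold higher number from compound 1 to compound 2 (0.12 log units; within the scatter). Compound 3 gives 1200 nM in this assay, a number that stays within the scatter of compound 1 but lies beyond it relative to compound 2. Compound 4 has not been measured. It differs from compound 3 by 1H-1,2,4-triazol-1-yl in place of methylsulfonyl on an aromatic carbon, the same change that separates compound 2 from compound 1. The step to compound 4 is expected to be a 1.3-fold higher number from compound 3 to compound 4 (0.12 log units; within the scatter), a size that rests on the earlier step of a 1.3-fold higher number from compound 1 to compound 2 (0.12 log units; within the scatter). Among the measured compounds shown here, compound 4 is therefore estimated at 1600 nM in this assay, with a range from 800 nM to 3500 nM, kept wide because the step of a 1.3-fold higher number from compound 1 to compound 2 (0.12 log units; within the scatter) was within the scatter and is the only example of this change that has been measured.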

Compound 4, half-maximal effective concentration: 400 nM
For compound 4 the middle estimate is 4.0-fold (0.60 log units) above the measured one; the whole stated range lies above it.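

In this assay, putting 1H-1,2,4-triazol-1-yl in place of methylsulfonyl on an aromatic carbon gave a 3.0-fold lower number from compound 3 to compound 4 (0.48 log units; beyond the scatter), and this step does not match the one measured on the other core: the same change on two cores in this assay, a 1.3-fold higher number (0.12 log units; within the scatter) from compound 1 to compound 2 and a 3.0-fold lower number (0.48 log units; beyond the scatter) from compound 3 to compound 4, 3.9-fold (0.60 log units) apart, beyond the scatter of two such steps. The size of this change therefore did not carry from the core of compound 1 to the core of compound 3, so in this series a step read on one of these cores cannot simply be applied to the other. Among the compounds shown here, it does not show what makes the two cores behave differently, and with only one pair on each core it gives no general rule for how this change behaves on either of them.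

From the compounds shown here alone, all four compounds keep the ethyl ester and the nitro group, so it remains open whether the step would hold with a carboxylic acid in place of the ester or an amine in place of the nitro group. Going by these compounds, it is also open how a nitrile or a small amide in place of the triazolyl would compare on these two cores.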